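Adding a Second Chloro Group to Compound 3

A few compounds are considered here, and "the series" means these few. Any claim that something is new, unique, unknown or untested is made for them only; others in the source may bear on it.

Compound 1 `O=[N+]([O-])c1ccc(Nc2nccc(-c3ccc(Br)cc3)n2)cc1` gives 25700 nM in a functional assay on HeLa cells (Homo sapiens) for antiproliferative activity, read by MTT assay; on this read-out lower numbers stand for stronger inhibition and higher numbers for weaker inhibition. Compound 2 `COc1ccc(-c2ccnc(Nc3ccc(Cl)cc3)n2)cc1` gives 310 nM in this assay. Compound 3 `Clc1ccc(Nc2nccc(-c3ccc(Br)cc3)n2)cc1` gives 36700 nM in this assay.

Among these three numbers, compound 3 carries the highest. Its gap to compound 1 is small, a 1.4-fold higher number from compound 1 to compound 3 (0.15 log units; within the scatter), so those two cannot be told apart. Its gap to compound 2 is large, a 120-fold higher number from compound 2 to compound 3 (2.07 log units; beyond the scatter), which is the only clear difference in the set.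

Compound 4 `Clc1ccc(Nc2nccc(-c3ccc(Br)cc3)n2)c(Cl)c1` differs from compound 3 by one change: chloro in place of hydrogen on an aromatic carbon. For the measured compounds named here, no measured step adds a second chloro group on that ring, so nothing bears on this change directly. Going by the values given here, the one step that altered a group on that ring, a 1.4-fold higher number from compound 1 to compound 3 (0.15 log units; within the scatter), stayed within the scatter, and the large step of a 120-fold higher number from compound 2 to compound 3 (2.07 log units; beyond the scatter) concerns a group elsewhere in the molecule. Compound 4 is therefore expected to sit close to compound 3, with no step beyond the scatter, a 1.2-fold lower number from compound 3 to compound 4 (0.09 log units; within the scatter). In this assay compound 4 is estimated at 30000 nM, within a range from 10000 nM to 90000 nM.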

Compound 4, half-maximal inhibitory concentration: 1080 nM
Estimate against measurement, compound 4: 28-fold (1.44 log units) above; the whole stated range lies above it.
By their numbers in this assay, from the lowest: compound 2; then compound 4; then compounds 1 and 3 (each within the scatter of the next).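

Placing a chloro group on an aromatic carbon of the ring that already carries one, ortho to a large group and meta to that first chloro group, gives a 34-fold lower number from compound 3 to compound 4 (1.53 log units; beyond the scatter) in this assay. For the compounds shown here, the only earlier change on this ring, a 1.4-fold higher number from compound 1 to compound 3 (0.15 log units; within the scatter), stayed within the scatter, so that ring had seemed to tolerate change without much effect, whereas this single added atom produces a large step. Nothing shown here explains why this hydrogen-to-chloro change has such a large effect.

From the compounds shown here alone, it remains open whether the gain is specific to chloro or would also appear with a fluoro, a methyl or an amine group at this place. Going by these compounds, it is also open whether the same added chloro group would lower the number further in compound 2, which carries methoxy in place of bromo.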